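From Ethylamino to Piperidin-1-yl in a Weakly Active Set

The compounds below may be only part of what the source reports. "The series", "measured", "known", "first", "only" and "open" are said of these compounds alone.

Of the compounds shown here, three have been measured so far in a functional assay on MGC-803 cells (Homo sapiens) for inhibition; a higher number here means a weaker inhibitor, a lower number a stronger inhibitor. Compound 1 `O=C(CC(CC(=O)NC1Cc2ccccc2C1)c1ccccc1)NCCN1CCCCC1` gives > 100000 nM, which is a limit and not a number. Compound 2 `CCN(C(=O)CC(CC(=O)NCCN1CCCCC1)c1ccc(Cl)cc1)C1Cc2ccccc2C1` gives a true number, 21200 nM. Compound 3 `CCNCCNC(=O)CC(CC(=O)N(CC)C1Cc2ccccc2C1)c1ccccc1` gives > 100000 nM, again only a limit. This places compound 3 at the limit of > 100000 nM in this assay, at which 2 of the 3 values shown sit.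

Compound 4 `CCN(C(=O)CC(CC(=O)NCCN1CCCCC1)c1ccccc1)C1Cc2ccccc2C1` is still unmeasured. It has piperidin-1-yl in place of ethylamino, on a saturated chain carbon, two bonds along the chain from an amide-type nitrogen: piperidin-1-yl in place of ethylamino on a saturated chain carbon, two bonds along the chain from an amide-type nitrogen.

Compound 2 carries the same 2-(piperidin-1-yl)ethyl and gives 21200 nM, so some measurable inhibition seems possible for compound 4. Compound 1 also carries that group, yet reaches only a limit, which goes against this and keeps the expectation modest. The expected at least 1.6-fold lower number from compound 3 to compound 4 (0.22 log units; that floor lies within the scatter) is a small move toward stronger inhibition, and its true size is uncertain.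

For compound 4 the estimated value in this assay is 60000 nM, with an expected range of 20000 nM to 100000 nM.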

Compound 4, half-maximal inhibitory concentration: > 100000 nM
Compound 4 was reported as a limit; the forecaster's own chance of this, stated with the estimate: 45%; at least 1.6-fold (0.22 log units) between middle value and limit.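

Putting hydrogen in place of chloro on an aromatic carbon gives an at least 4.7-fold higher number from compound 2 to compound 4 (0.67 log units; beyond the scatter) in this assay, so 2-(piperidin-1-yl)ethyl alone does not give compound 4 a measurable value like that of compound 2. The steps to compound 4 from compound 3 and from compound 1 cannot be read, as both ends of each step are limits. Piperidin-1-yl in place of ethylamino on this saturated chain carbon therefore shows no readable gain, and most of the set remains at a limit: the limit of > 100000 nM in this assay, at which 3 of the 4 values shown sit.

From the compounds shown here alone, how far the true values of these limit compounds lie from one another remains open, and so does the real size of the change from ethylamino to piperidin-1-yl. Also open, going by these compounds, is whether bromo or methyl on that aromatic carbon would give a measurable number, as chloro does.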